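Swapping Dichlorophenyl for Dimethoxyphenyl in a Cell Test

The source may hold more compounds than are shown below. What is called first, only, known or untested is meant among the compounds shown, and "the series" means these compounds.

Compound 1 `Nc1cc(N)c2nc(-c3ccccc3)c(NCc3ccc(Cl)c(Cl)c3)nc2c1` was tested in a functional assay on NCI-H226 cells (Homo sapiens) for inhibition, read by sulforhodamine B assay, with a stated time of 48 h (on this read-out higher numbers stand for lower toxicity in this test and lower numbers for higher toxicity in this test), where compound 1 gives 95500 nM. Going by the values given here, that is the only plain number among the measured values; the other entry is a limit. Compound 2 `Nc1cc(N)c2nc(-c3ccccc3)c(Sc3ccc(Cl)c(Cl)c3)nc2c1` was tested alongside it, and in this assay compound 2 gives < 100000 nM, which is a limit of the assay rather than a number. Among the compounds with values here, the single piece of evidence available is the limit of < 100000 nM in this assay, at which 1 of the 2 values shown sits.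

Compound 3 `COc1ccc(CNc2nc3cc(N)cc(N)c3nc2-c2ccccc2)cc1OC` has not yet been measured. It differs from compound 1 by 3,4-dimethoxyphenyl in place of 3,4-dichlorophenyl on a saturated chain carbon bound to a nitrogen on an aromatic ring. Within the data shown here, no step between two measured compounds is available, so the effect of this swap cannot be read from a measured pair. Both measured compounds sit at or close to the top of the range, which suggests the shared core tolerates a change of this kind without a large move in either direction. The step from compound 1 to compound 3 is expected to be a 1.0-fold higher number from compound 1 to compound 3 (0.02 log units; within the scatter), none beyond the scatter. Compound 3 is estimated at 100000 nM, with a range from 40000 nM to 250000 nM.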

Compound 3, concentration lethal to 50% of the cells: 64600 nM
The estimate for compound 3 lay 1.5-fold (0.19 log units) above the measured number; measured number inside the range.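

In this assay, going by these compounds alone, this is the first pair of measured compounds that differ in one place, and it gives a 1.5-fold lower number from compound 1 to compound 3 (0.17 log units; within the scatter). The change is 3,4-dimethoxyphenyl in place of 3,4-dichlorophenyl on a saturated chain carbon bound to a nitrogen on an aromatic ring, so this position accepts a larger group, with 10 heavy atoms instead of 8 and 2 hydrogen-bond acceptors instead of 0, without a change that can be told from the usual scatter of the test. Nothing measured here gives a reason for the size of this step.

On these data alone, what a group of a different kind would do at this place stays open: an unsubstituted phenyl, a ring bearing a carboxylic acid or an amine, or a longer chain could each still move the number beyond the scatter. As far as these compounds go, whether the same swap would behave alike in compound 2 also stays open: compound 2 gives < 100000 nM, which is a limit of the assay and not a number.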